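This account rests on a few compounds, and the source may have more. Where it says the series, first, only, none or still open, it means among the compounds named here.

Measured so far in a functional assay on cardiac atrium for agonist activity at histamine H2 receptor (Cavia porcellus); on this read-out lower numbers stand for lower potency and higher numbers for higher potency (the scale is a negative logarithm):
compound 1 `N=C(NCCCc1c[nH]cn1)NCCC(c1ccc(Cl)cc1)c1ccccn1` gives 7.84
compound 2 `N=C(NCCCc1c[nH]cn1)NCCC(c1ccc(Br)cc1)c1ccccn1` gives 7.48
compound 3 `N=C(NCCCc1c[nH]cn1)NCCC(c1cccc(F)c1)c1ccccn1` gives 7.88

Compound 3 holds the highest number of the three, but its gap to compound 1 lies within the scatter, so the two cannot be ordered; only compound 2 sits clearly below, as the step of a number 0.40 log units higher from compound 2 to compound 3 (beyond the scatter) shows. The unmeasured compound 4 `N=C(NCCCc1c[nH]cn1)NCCC(c1cccc(C(F)(F)F)c1)c1ccccn1` arises from compound 3 by trifluoromethyl in place of fluoro on an aromatic carbon. Going by the values given here, no measured step covers this kind of change. The nearest guide is a number 0.36 log units lower from compound 1 to compound 2 (beyond the scatter), where one halogen replaced another on the same ring and the number fell modestly, while a number 0.04 log units higher from compound 1 to compound 3 (within the scatter) shows that moving a different halogen to a different position left the number essentially unchanged. These hints are indirect, so the step to compound 4 in this assay is expected to be small, with a slight lean downward: a number 0.28 log units lower from compound 3 to compound 4 (within the scatter). Compound 4 is therefore estimated at 7.6, within a range from 7.1 to 8.1.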

Compound 4, negative logarithm of the half-maximal effective concentration: 7.43
The estimate for compound 4 lay 0.17 log units above the measured number; the measured number falls inside the stated range.
By their numbers in this assay, from the lowest: compounds 4 and 2 (each within the scatter of the next); then compounds 1 and 3 (each within the scatter of the next).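

In this assay the place on the aromatic ring held by fluoro in compound 3 does not tolerate every replacement: with trifluoromethyl there, 4 heavy atoms entering for 1, the result is a number 0.45 log units lower from compound 3 to compound 4 (beyond the scatter). Against the two 4-halophenyl compounds the picture splits, with a number 0.41 log units lower from compound 1 to compound 4 (beyond the scatter) and a number 0.05 log units lower from compound 2 to compound 4 (within the scatter), so 3-(trifluoromethyl)phenyl and 4-bromophenyl cannot be ordered here, and both sit clearly under 3-fluorophenyl and 4-chlorophenyl. The available evidence offers no explanation for this fall.

The compounds shown leave open how a methyl, a methoxy or a nitrile in the same place would read. They also leave open whether fluoro to trifluoromethyl would give a similar step on another core.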